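The source may hold more compounds than are shown below. What is called first, only, known or untested is meant among the compounds shown, and "the series" means these compounds.

Measured compounds in a physicochemical assay for solubility, in phosphate buffer, at pH 7.4; on this read-out lower numbers stand for lower solubility and higher numbers for higher solubility:

Compound 1, `CCOC(=O)c1c(-c2cccc(Cl)c2)[nH]c2cccc(OC)c2c1=O`, gives > 100000 nM, which is a limit of the assay and not a number.
Compound 2, `CCOC(=O)c1c(-c2cccc(F)c2)[nH]c2cc(OC)ccc2c1=O`, gives > 100000 nM, again a limit rather than a number.
Compound 3, `CCOC(=O)c1c(-c2ccccc2C)[nH]c2cc(OC)ccc2c1=O`, gives > 100000 nM, also a limit of the assay.

So for compound 3 only a limit is known, and the two further values around it are limits as well: all three sit at the same end of this assay (the limit of > 100000 nM in this assay, at which 3 of the 3 values shown sit). Within the data shown here, the one step among them that differs in a single place, a step that the two limits leave unreadable from compound 2 to compound 3, is therefore unreadable in size, since both ends are limits.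

Compound 4, `CCOC(=O)c1c(-c2ccccc2Cl)[nH]c2cc(OC)ccc2c1=O`, has not yet been measured. It differs from compound 3 as follows: chloro in place of methyl on an aromatic carbon. Among the measured compounds shown here, no measured step bears directly on a chloro in place of a methyl here; the only single-place step available, a step that the two limits leave unreadable from compound 2 to compound 3, tells nothing of its size. What the three values do show is that the shared core with each of three different aryl groups reaches the limit of this assay (the limit of > 100000 nM in this assay, at which 3 of the 3 values shown sit).

On that basis compound 4 is expected to stay near the limit too, and the estimated step of a number no higher from compound 3 to compound 4 (the limit leaves the size open) is accordingly none beyond the scatter. The estimate for compound 4 in this assay is 100000 nM, with a range from 30000 nM to 300000 nM.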

Compound 4, solubility: 28000 nM
For compound 4 the middle estimate is 3.6-fold (0.55 log units) above the measured one; the measured number lies below the stated range.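

In this assay, among these compounds, chloro in place of methyl, on an aromatic carbon of a six-membered aromatic ring of carbon only and ortho to a large group, gives the first change whose size can be at least partly read: an at least 3.5-fold lower number from compound 3 to compound 4 (0.55 log units; beyond the scatter). The 2-chlorophenyl group also parts from the 3-fluorophenyl group, with an at least 3.5-fold lower number from compound 2 to compound 4 (0.55 log units; beyond the scatter), so the choice of aryl group on the shared core can move this read-out beyond the scatter. Compound 4 alone among the four gives a number, and each step remains a minimum because its starting compound stands at a limit of the assay: the limit of > 100000 nM in this assay, at which 3 of the 4 values shown sit.

As far as these compounds go, the step from compound 2 to compound 3 still cannot be read, and the full distance from either compound to compound 4 remains unknown. The compounds shown also leave open whether bromo, methoxy or an amine at this place would follow chloro or methyl in this assay, and what a carboxylic acid or an amide in place of the ethyl ester would give.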